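Swapping trihydroxyphenyl for dichlorophenyl on a weak inhibitor

The compounds below may be only part of what the source reports. "The series", "measured", "known", "first", "only" and "open" are said of these compounds alone.

compound 1 `Cc1ccc(CS/C(=C/c2c(O)cc(O)cc2O)C(=O)c2ccc(Cl)cc2)cc1` gives 50000 nM
compound 2 `Cc1ccc(S(=O)(=O)/C(=C/c2c(O)cc(O)cc2O)C(=O)c2ccc(Cl)cc2)cc1` gives > 100000 nM, a limit
compound 3 `Cc1ccc(CS/C(=C/c2cccc(Cl)c2Cl)C(=O)c2ccc(Cl)cc2)cc1`, not yet measured

In a functional assay on DU-145 cells (Homo sapiens) for inhibition, read by trypan blue exclusion, with a stated time of 96 h (on this read-out higher numbers stand for weaker inhibition of growth and lower numbers for stronger inhibition of growth), compound 1 gives 50000 nM, the only number shown in the set. Among the measured compounds shown here, the one other value shown belongs to compound 2, which in this assay reaches only the limit > 100000 nM. For the measured compounds named here, the single measured step, an at least 2.0-fold higher number from compound 1 to compound 2 (0.30 log units; that floor lies within the scatter), runs up to the limit of > 100000 nM in this assay, at which 1 of the 2 values shown sits, and concerns (4-methylphenyl)sulfonyl in place of (4-methylbenzyl)sulfanyl on a double-bonded chain carbon bound to a carbonyl carbon and a double-bonded chain carbon; it leaves the aryl group untouched.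

Compound 3 differs from compound 1 by 2,3-dichlorophenyl in place of 2,4,6-trihydroxyphenyl on a double-bonded chain carbon bound to a double-bonded chain carbon. Going by the values given here, no measured step bears on this kind of change, so the data give no direction for it. The step of a 1.3-fold lower number from compound 1 to compound 3 (0.10 log units; within the scatter) is therefore expected to stay within the scatter. The estimate for compound 3 in this assay is 40000 nM, with a range from 8000 nM to 150000 nM.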

Compound 3, concentration for 50% growth inhibition: 25000 nM
Compound 3: the middle estimate sits 1.6-fold (0.20 log units) above what was measured, within the range that was stated.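

In this assay, among the compounds shown here, this is the first reading of a change at the aryl group on the double-bonded chain carbon, as the earlier step left that group untouched. The step, a 2.0-fold lower number from compound 1 to compound 3 (0.30 log units; within the scatter), lies within the scatter, so 2,3-dichlorophenyl and 2,4,6-trihydroxyphenyl cannot be told apart at this place, even though the entering group counts 0 hydrogen-bond donors against 3 for the group that leaves. Compound 3 has a measured number, whereas the one limit of the assay in this set belongs to compound 2: the limit of > 100000 nM in this assay, at which 1 of the 3 values shown sits.

From the compounds shown here alone, whether a phenyl group carrying an amine or a carboxylic acid at this place would give a number beyond the scatter stays open. Also open, going by these compounds, is whether 2,3-dichlorophenyl would read the same alongside the (4-methylphenyl)sulfonyl group of compound 2, which would show whether the two changes act independently.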